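A few compounds are considered here, and "the series" means these few. Any claim that something is new, unique, unknown or untested is made for them only; others in the source may bear on it.

Measured compounds:
- compound 1, `O=C(CN(C(=O)C1CCCCC1)C1CCCCC1)Nc1cc(F)cc(F)c1`, in an assay on HEK293 cells for inhibition of sodium- and chloride-dependent glycine transporter 1 (Homo sapiens), read by scintillation proximity assay (on this read-out higher numbers stand for weaker inhibition and lower numbers for stronger inhibition), compound 1 gives 6310 nM
- compound 2, `O=C(CN(C(=O)c1ccc(-c2ccccn2)cc1)C1CCCCC1)Nc1cc(F)cc(F)c1`, in this assay compound 2 gives 63.1 nM
- compound 3, `O=C(CN(C(=O)c1ccc(-c2ccccn2)cc1)C1CCOCC1)Nc1cc(F)cc(F)c1`, in this assay compound 3 gives 1000 nM

Compound 3 holds the second highest number of the three, so only compound 1 shows weaker inhibition, and compound 2 stands well below both. For the measured compounds named here, the one step that touches the group on the amide-type nitrogen is a 16-fold higher number from compound 2 to compound 3 (1.20 log units; beyond the scatter), which shows that exchanging a carbon ring for an oxygen-containing ring at this position costs a great deal of inhibition.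

Compound 4, `CCC(COC)N(CC(=O)Nc1cc(F)cc(F)c1)C(=O)c1ccc(-c2ccccn2)cc1`, differs from compound 3 by 1-(methoxymethyl)propyl in place of oxan-4-yl on an amide-type nitrogen. The ring is opened into a branched chain of the same size, and the single oxygen acceptor is kept. Going by the values given here, no measured step covers an open chain at this nitrogen, so the only guidance is that this position is sensitive, as the change from compound 2 to compound 3 showed. With the oxygen retained, compound 4 is expected to stay close to compound 3, and the step of a 1.5-fold higher number from compound 3 to compound 4 (0.18 log units; within the scatter) is estimated to lie within or only slightly beyond the scatter.

The value for compound 4 in this assay is therefore estimated at 1500 nM, with a range from 400 nM to 6000 nM.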

Compound 4, half-maximal inhibitory concentration: 1260 nM
Estimate against measurement, compound 4: 1.2-fold (0.08 log units) above; the range from low to high includes it.
By their numbers in this assay, from the lowest: compound 2; then compounds 3 and 4 (each within the scatter of the next); then compound 1.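

In this assay the step is a 1.3-fold higher number from compound 3 to compound 4 (0.10 log units; within the scatter), so at this amide-type nitrogen the ring of oxan-4-yl and the open chain of 1-(methoxymethyl)propyl cannot be told apart. Set against cyclohexyl, the open chain gives a 20-fold higher number from compound 2 to compound 4 (1.30 log units; beyond the scatter), which means the large gap first seen with compound 3 also appears with a second oxygen-bearing group, one that has no ring at all. Nothing at hand explains why these two groups give such similar results.

The compounds shown do not say whether the oxygen itself accounts for the gap to cyclohexyl, or whether something else about these two groups does. An all-carbon chain such as pentan-3-yl would separate the open shape from the oxygen, and a piperidin-4-yl ring, with an amine nitrogen where oxan-4-yl has its oxygen, would test whether a different hetero atom at that spot in the ring gives the same result.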